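A side-chain swap at the assay limit

A few compounds are considered here, and "the series" means these few. Any claim that something is new, unique, unknown or untested is made for them only; others in the source may bear on it.

Compounds measured so far in an ADME assay on a cell-free system (plasma, Homo sapiens) for metabolic stability, tested at 1 uM; on this read-out lower numbers stand for a shorter-lived compound and higher numbers for a longer-lived compound
Compound 1 `C=CC(=O)NCC1CCN(S(=O)(=O)c2ccc(NC(=O)OCc3ccccc3)cc2)CC1` gives > 6 h
Compound 2 `C=CC(=O)NC1CCN(S(=O)(=O)c2ccc(C(=O)N[C@@H]3C[C@H]3c3ccccc3)cc2)CC1` gives > 6 h

Compound 2 stands at > 6 h in this assay and that figure is a limit of the assay, not a number. Compound 1 stands at > 6 h and that figure is also a limit. Everything measured so far therefore sits at one mark (the limit of > 6 h in this assay, at which 2 of the 2 values shown sit), and no step between two measured compounds is available to show how large a change can be.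

Compound 3 `C=CC(=O)NC1CCN(S(=O)(=O)c2ccc(C(=O)NCCC3CCCCC3)cc2)CC1` keeps the core of compound 2 and alters one group (2-cyclohexylethyl in place of 2-phenylcyclopropyl on an amide-type nitrogen), with 2-cyclohexylethyl in place of 2-phenylcyclopropyl on an amide-type nitrogen.

With only the limit of compound 2 at > 6 h as a starting point, no change beyond the usual scatter is expected, and neither direction is favoured. The estimated step that the limit leaves unreadable from compound 2 to compound 3 is expected to stay within that scatter. Compound 3 is estimated at 7 h in this assay with an expected range from 4 h to 12 h and the assay is expected to report only a limit again.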

Compound 3, half-life: > 6 h
Compound 3 ended at the assay's limit; the forecaster's own chance of this, stated with the estimate: 85%; the middle value does not contradict the limit.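

In this assay compound 3 gives > 6 h, which is a limit of the assay and not a number. Compound 2 also stands at a limit, so no step can be read from compound 2 to compound 3, and all the compounds shown share one mark: the limit of > 6 h in this assay, at which 3 of the 3 values shown sit.

The compounds shown leave open what half-life each truly has, and whether 2-cyclohexylethyl in place of 2-phenylcyclopropyl on an amide-type nitrogen changes it at all.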